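The source may hold more compounds than are shown below. What is called first, only, known or untested is meant among the compounds shown, and "the series" means these compounds.

The measured compounds:
compound 1 `CC(C)[C@H]1CC[C@@](O)(CO)[C@H]2C(=O)OCC(C(=O)O)=C[C@H]12` — in a functional assay on WM 266-4 cells (Homo sapiens) for inhibition, with a stated time of 72 h (on this read-out higher numbers stand for weaker inhibition and lower numbers for stronger inhibition), compound 1 gives only a limit of the assay, > 32000 nM.
compound 2 `CC(C)[C@H]1CC[C@@](O)(CCl)[C@H]2C(=O)OCC(C(=O)O)=C[C@H]12` — in this assay compound 2 gives 550 nM.
compound 3 `COC(=O)C1=C[C@@H]2[C@@H](C(C)C)CC[C@@]3(CO3)[C@H]2C(=O)OC1` — in this assay compound 3 gives 4100 nM.

Compound 3 therefore stands highest of the two numbers, with compound 2 below it by a gap beyond the scatter, while compound 1 offers only a limit of > 32000 nM in this assay, at which 1 of the 3 values shown sits, and cannot be placed.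

Compound 4 `CNC(=O)C1=C[C@@H]2[C@@H](C(C)C)CC[C@@]3(CO3)[C@H]2C(=O)OC1` differs from compound 3 in one place: methylamino in place of methoxy on a carbonyl carbon. Among the measured compounds shown here, the only measured step, an at least 58-fold lower number from compound 1 to compound 2 (1.76 log units; beyond the scatter), concerns a chain carbon on the core and a different pair of groups, so it does not bear on this exchange at the carbonyl carbon. For the measured compounds named here, no measured pair compares methoxy with methylamino there. With nothing to point either way, the expectation for this step is no change beyond the scatter, no change at the digits printed from compound 3 to compound 4 (within the scatter). Compound 4 is thus estimated at 4100 nM, with a range from 1300 nM to 13000 nM.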

Compound 4, half-maximal inhibitory concentration: 5900 nM
Compound 4: the middle estimate sits 1.4-fold (0.16 log units) below what was measured; the measured number falls inside the stated range.
By their numbers in this assay, from the lowest: compound 2; then compounds 3 and 4 (each within the scatter of the next). At a limit, above all of these: compound 1.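

Methylamino in place of methoxy on a carbonyl carbon gives a 1.4-fold higher number from compound 3 to compound 4 (0.16 log units; within the scatter) in this assay, the first direct reading of any exchange at this place. In this one pair, the methoxy group, counted with a hydrogen-bond acceptor, gives way to the methylamino group, counted with a hydrogen-bond donor, and the read-out does not move beyond the scatter, so this position accepts methylcarbamoyl for methoxycarbonyl on the shared core. Nothing measured here bears on why this exchange leaves the number within the scatter.

As far as these compounds go, what remains open is whether larger groups on this carbonyl carbon, such as dimethylamino or a longer chain like butylamino, would read the same way. From the compounds shown here alone, it is also open whether methylamino would behave alike on a compound carrying the chloro group of compound 2.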